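The compounds below may be only part of what the source reports. "The series", "measured", "known", "first", "only" and "open" are said of these compounds alone.

Compound 1, `Cc1c(C(=O)N(C)C)oc2ccc(Nc3ncnc4ccc(Cl)nc34)cc12` — in an assay on isolated protein for inhibition of MAP kinase-interacting serine/threonine-protein kinase 1 (Homo sapiens), read by HTRF, in the presence of a further agent that is not named here (on this read-out lower numbers stand for stronger inhibition and higher numbers for weaker inhibition), compound 1 gives > 10000 nM, a limit of the assay.
Compound 2, `Cc1c(C(=O)N2CCNCC2)oc2ccc(Nc3ncnc4ccc(Cl)nc34)cc12` — in this assay compound 2 gives > 10000 nM, also a limit of the assay.

For the measured compounds named here, compound 2 therefore stands only at a limit, and so does the one compound it can be compared with: both sit at the limit of > 10000 nM in this assay, at which 2 of the 2 values shown sit. The step that the two limits leave unreadable from compound 1 to compound 2 is left unreadable by the two limits. Compound 3, `CNC(=O)c1oc2ccc(Nc3ncnc4ccc(Cl)nc34)cc2c1C`, differs from compound 2 by methylamino in place of piperazin-1-yl on a carbonyl carbon. Going by the values given here, the only measured step touching the same carbonyl carbon gives no readable size, so no shift beyond the scatter can be foreseen in this assay, and a further limit is the likeliest outcome. Compound 3 is thus estimated at 20000 nM (range 5000 nM to 100000 nM), a step that the limit leaves unreadable from compound 2 to compound 3 that is expected, not measured.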

Compound 3, half-maximal inhibitory concentration: > 10000 nM
Compound 3 was reported as a limit (the forecaster's own chance of this, stated with the estimate: 85%); the middle value lies beyond the limit too.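

No new step can be read among compound 1, compound 2 and compound 3, because all three sit at one limit: the limit of > 10000 nM in this assay, at which 3 of the 3 values shown sit. The compounds shown leave open how strongly each inhibits the kinase, and whether the group on the carbonyl carbon changes that.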